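This account rests on a few compounds, and the source may have more. Where it says the series, first, only, none or still open, it means among the compounds named here.

Compounds measured in an ADME assay on microsomes from liver (Homo sapiens) for metabolic stability, read by LC-MS, using NADPH, with a stated time of 30 min, tested at 1 uM; a lower number here means slower removal, a higher number faster removal of the compound:
- compound 1, `Cc1cc2c(cn1)Oc1ccc(NC(=O)c3ccc(Cl)cn3)cc1[C@@]21COC(N)=N1`: 16 mL.min-1.g-1
- compound 2, `COc1cc2c(cn1)Oc1ccc(NC(=O)c3ccc(Cl)cn3)cc1[C@@]21COC(N)=N1`: < 14 mL.min-1.g-1
- compound 3, `CC#Cc1cncc(-c2ccc3c(c2)[C@@]2(COC(N)=N2)c2cc(C4=CCCOC4)ncc2O3)c1`: 76 mL.min-1.g-1

Compound 1 gives 16 mL.min-1.g-1 in this assay. Compound 2 is reported only as a limit of the assay, < 14 mL.min-1.g-1, so no exact number is known for it. Compound 3, which carries a different set of substituents on the shared core, gives 76 mL.min-1.g-1. Compound 2 therefore stands at the low edge of what the assay can resolve, consistent with the limit of < 14 mL.min-1.g-1 in this assay, at which 1 of the 3 values shown sits.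

Among the compounds with values here, the one measured step that touches the same position, an at least 1.1-fold lower number from compound 1 to compound 2 (0.05 log units; that floor lies within the scatter), is too small to separate from the scatter. Compound 4, `NC1=N[C@@]2(CO1)c1cc(NC(=O)c3ccc(Cl)cn3)ccc1Oc1cnc(C3CC3)cc12`, differs from compound 2 by cyclopropyl in place of methoxy on an aromatic carbon. Within the data shown here, no measured pair shows a cyclopropyl at this position, so the step from compound 2 to compound 4 in this assay rests on the methyl-to-methoxy comparison alone. The expected step is an at least 1.5-fold higher number from compound 2 to compound 4 (0.19 log units; that floor lies within the scatter), a modest rise that may still sit within the scatter. Compound 4 is estimated at 22 mL.min-1.g-1, within 10 mL.min-1.g-1 to 48 mL.min-1.g-1.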

Compound 4, intrinsic clearance in microsomes: < 14 mL.min-1.g-1
Compound 4: a limit, no number; the forecaster's own chance of this, stated with the estimate: 25%; middle value at least 1.5-fold (0.19 log units) away from the limit.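

With cyclopropyl on this aromatic carbon, next to the ring nitrogen, compound 4 is also reported only as a limit of the assay in this assay, so a three-membered ring of carbon here leaves the read-out where methoxy left it, and the step between these two limits cannot be read. Cyclopropyl in place of methyl gives an at least 1.1-fold lower number from compound 1 to compound 4 (0.05 log units; that floor lies within the scatter), so this change too cannot be told apart from repeat measurement. The low edge of the assay now holds both the methoxy and the cyclopropyl compound: the limit of < 14 mL.min-1.g-1 in this assay, at which 2 of the 4 values shown sit.

From the compounds shown here alone, how far compound 2 and compound 4 lie beyond that limit stays open, and with it any order between methoxy and cyclopropyl at this position. Also open, going by these compounds, is whether an amine or a carboxylic acid on this carbon would bring the read-out back into the range the assay can resolve.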